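Allyl to Benzyl on the Sulfur of Compound 2

A few compounds are considered here, and "the series" means these few. Any claim that something is new, unique, unknown or untested is made for them only; others in the source may bear on it.

Compound 2 `C=CCSc1nnc(-c2cc(OC)c(OC)c(OC)c2)n1N1C(=O)c2ccccc2C1=O` gives > 200000 nM in a functional assay on PC-3M cells (Homo sapiens) for cytotoxicity, read by MTT assay, with a stated time of 48 h (on this read-out higher numbers stand for weaker inhibition and lower numbers for stronger inhibition), a value that is a limit of the assay and not a number. Compound 1 `C#CCSc1nnc(C)n1N1C(=O)c2ccccc2C1=O`, which shares the same core, also gives > 200000 nM in this assay, again only a limit. Going by the values given here, both measured values thus rest at the limit of > 200000 nM in this assay, at which 2 of the 2 values shown sit, so compound 2 stands together with the only other measured compound at the edge of what this assay could resolve. Compound 3 `COc1cc(-c2nnc(SCc3ccccc3)n2N2C(=O)c3ccccc3C2=O)cc(OC)c1OC` differs from compound 2 by phenyl in place of vinyl on a saturated chain carbon bound to a sulfur, that is, allyl to benzyl on the sulfur. Among the compounds with values here, no step between measured compounds exists to guide this change, as both sit at a limit. The expected step is a number no higher from compound 2 to compound 3 (the limit leaves the size open), none beyond the scatter. Compound 3 is therefore estimated at 200000 nM, within a range from 50000 nM to 400000 nM, and most probably reported once more only as a limit.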

Compound 3, half-maximal inhibitory concentration: > 200000 nM
Compound 3: no number, only a limit; the forecaster's own chance of this, stated with the estimate: 75%; the middle value lies on the limit itself.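

Compound 3 gives > 200000 nM in this assay, which is a limit of the assay and not a number. With compound 2 also at a limit, no step can be read for allyl to benzyl on the sulfur. The compounds shown leave open how any change on the shared core would shift the value, as all rest at one limit: the limit of > 200000 nM in this assay, at which 3 of the 3 values shown sit.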